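From aryl amidine to bare amidine: compound 2 to compound 4

The source may report more compounds than this note shows. Statements on the series, on what has been measured and on what is new or still open speak of the compounds shown alone.

Three close relatives of one shared core have been tested in a functional assay on MCF7 cells (Homo sapiens) for cytotoxicity, read by MTT assay, with a stated time of 48 h; a higher number here means a weaker inhibitor, a lower number a stronger inhibitor. Compound 1 `Cc1ccc(S(=O)(=O)/N=C(/CCNC2=CC(=O)c3ccccc3C2=O)Nc2ccc(Cl)cc2)cc1` gives 7080 nM. Compound 2 `Cc1ccc(S(=O)(=O)/N=C(/CCNC2=CC(=O)c3ccccc3C2=O)Nc2ccccc2I)cc1` gives 15500 nM, and compound 3 `Cc1ccc(S(=O)(=O)/N=C(/CCNC2=CC(=O)c3ccccc3C2=O)Nc2ccc(Cl)cc2Cl)cc1` gives 17000 nM. Compound 2 thus stands second highest of the three numbers: the step of a 2.2-fold higher number from compound 1 to compound 2 (0.34 log units; beyond the scatter) lies beyond the scatter, whereas the step of a 1.1-fold higher number from compound 2 to compound 3 (0.04 log units; within the scatter) stays within it. Compound 4 `Cc1ccc(S(=O)(=O)/N=C(\N)CCNC2=CC(=O)c3ccccc3C2=O)cc1` differs from compound 2 by hydrogen in place of 2-iodophenyl on an amine nitrogen. Among the measured compounds shown here, no measured step removes an aromatic ring from that amine nitrogen; the steps of a 2.2-fold higher number from compound 1 to compound 2 (0.34 log units; beyond the scatter) and a 2.4-fold higher number from compound 1 to compound 3 (0.38 log units; beyond the scatter) only exchange or add a substituent on a 2-iodophenyl or 4-chlorophenyl that stays in place, and both were modest. The data therefore give no direct guide to the loss of the whole ring, and the three measured numbers sit within a narrow band. A modest step toward a higher number is therefore expected, a 1.6-fold higher number from compound 2 to compound 4 (0.21 log units; within the scatter). Compound 4 is estimated at 25000 nM, within a range from 10000 nM to 60000 nM.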

Compound 4, half-maximal inhibitory concentration: 18600 nM
Estimate against measurement, compound 4: 1.3-fold (0.13 log units) above, within the range that was stated.
By their numbers in this assay, from the lowest: compound 1; then compounds 2, 3 and 4 (each within the scatter of the next).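

An aromatic ring on this amine nitrogen is not needed to reach the level seen with 2-iodophenyl or 2,4-dichlorophenyl: with hydrogen there, the result is a 1.2-fold higher number from compound 2 to compound 4 (0.08 log units; within the scatter) and a 1.1-fold higher number from compound 3 to compound 4 (0.04 log units; within the scatter). Only the 4-chlorophenyl ring stands apart from the bare amidine, with a 2.6-fold higher number from compound 1 to compound 4 (0.42 log units; beyond the scatter), a modest step that lies beyond the scatter. Within these four compounds, then, any benefit from a ring at this position is seen only for compound 1, and compound 2 and compound 3 go against a general claim that an aromatic ring helps.

No measurement at hand explains why the 4-chlorophenyl ring stands apart. Going by these compounds, it remains open whether a methyl or a benzyl group on this nitrogen would fall nearer compound 1 or compound 4.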